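The compounds below may be only part of what the source reports. "The series", "measured", "known", "first", "only" and "open" are said of these compounds alone.

Measured compounds:
compound 1 `Cc1ccccc1OCC(=O)Nc1ccc(OCC(=O)O)c(F)c1` gives "not determined" (no result reported) in a physicochemical assay for lipophilicity, using the shake flask method, at pH 7.4; on this read-out higher numbers stand for higher lipophilicity and lower numbers for lower lipophilicity;
compound 2 `Cc1cccc(OCC(=O)Nc2ccc(OCC(=O)O)c(F)c2)c1` gives -0.99 in this assay;
compound 3 `CCc1ccc(OCC(=O)Nc2ccc(OCC(=O)O)c(F)c2)cc1` gives "not determined" (no result reported) in this assay.

Compound 1 therefore stands without a number of its own: of the three measured compounds, only compound 2 carries a value in this assay, and compound 3, like compound 1, has none. Within the data shown here, no step between measured compounds is known.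

Compound 4 `Cc1ccc(C(C)C)cc1OCC(=O)Nc1ccc(OCC(=O)O)c(F)c1` differs from compound 1 by isopropyl in place of hydrogen on an aromatic carbon. Since compound 1 has no number, the step itself cannot be sized, but the change is expected to move compound 4 upward in this assay by more than the usual scatter, relative to where a methyl-bearing analogue such as compound 2 sits. Compound 4 is accordingly estimated at 0.3, within a range from -0.5 to 1.1.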

Compound 4, distribution coefficient: 0.47
For compound 4 the middle estimate is 0.17 log units below the measured one, and the stated range covers the measured number.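

In this assay, among these compounds, compound 1 gives "not determined" (no result reported) and so no step from it to compound 4 can be read. As far as these compounds go, how far isopropyl in place of hydrogen shifts this read-out stays open. No further evidence bears on this result.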